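The source may report more compounds than this note shows. Statements on the series, on what has been measured and on what is new or still open speak of the compounds shown alone.

Compound 1 `CCc1ccc(NC(=O)Nc2cc(C)nc3ccccc23)cc1`: 3300 nM
Compound 2 `Cc1cc(NC(=O)Nc2ccccc2C(C)(C)C)c2ccccc2n1`: 100 nM
Compound 3 `Cc1cc(NC(=O)Nc2cccc(C(F)(F)F)c2)c2ccccc2n1`: 100 nM

In a physicochemical assay for solubility, at pH 7.4 (a higher number here means a more soluble compound, a lower number a less soluble compound), compound 1 gives 3300 nM, the highest of the three numbers. Compound 2 and compound 3 both lie well below it, and each of those gaps is beyond the usual scatter of the measurement. Compound 4 `Cc1cc(NC(=O)Nc2ccc(C(=O)O)cc2)c2ccccc2n1` has not yet been measured. Set against compound 1 it shows one change: carboxy in place of ethyl on an aromatic carbon. For the measured compounds named here, no measured pair in this set shares that change, so nothing measured here shows its effect directly. The shift is nonetheless expected to be upward and larger than the scatter, a 7.6-fold higher number from compound 1 to compound 4 (0.88 log units; beyond the scatter). Compound 4 is therefore estimated at about 25000 nM, most likely between 6000 nM and 100000 nM.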

Compound 4, solubility: 9300 nM
Compound 4: middle estimate off by 2.7-fold (0.43 log units), on the high side; the measured number falls inside the stated range.
By their numbers in this assay, from the lowest: compounds 2 and 3 (each within the scatter of the next); then compound 1; then compound 4.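

In this assay, putting carboxy in place of ethyl on this aromatic carbon, para to a large group, gives a 2.8-fold higher number from compound 1 to compound 4 (0.45 log units; beyond the scatter). For the compounds shown here, this is the first direct reading of a change at this position, and it shows that the number can rise there through a swap of this one group, though the step is modest. No measurement here explains the rise. From the compounds shown here alone, whether an amine or a longer chain on the same carbon would shift the number in the same direction remains open. So does whether carboxy would give a similar step elsewhere on this ring.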